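Replacing the 3,4,5-trimethoxyphenyl of compound 1 with 3-nitrophenyl

The compounds below may be only part of what the source reports. "The series", "measured", "known", "first", "only" and "open" are said of these compounds alone.

In a functional assay on NALM-6 cells (Homo sapiens) for antiproliferative activity, read by MTT assay and trypan blue exclusion, with a stated time of 72 h (a higher number here means a weaker inhibitor, a lower number a stronger inhibitor), compound 1 (`COC(=O)c1ccc(C2SCC(=O)N2c2ccc(N3CCN(Cc4cc(OC)c(OC)c(OC)c4)CC3)cn2)c(OC)c1`) gives > 100000 nM, which is a limit of the assay and not a number. Compound 3 (`COC(=O)c1ccc(C2SCC(=O)N2c2ccc(N3CCN(Cc4cccc([N+](=O)[O-])c4)CC3)cn2)c(OC)c1`) carries 3-nitrophenyl in place of 3,4,5-trimethoxyphenyl on a saturated chain carbon bound to an amine nitrogen in a ring. Compound 2 (`COC(=O)c1ccc(C2SCC(=O)N2c2ccc(N3CCN(Cc4cccc(C)c4)CC3)cn2)c(OC)c1`), with 3-methylphenyl in that place, gives 27300 nM. Among the measured compounds shown here, the one measured step that bears on this change is an at least 3.6-fold lower number from compound 1 to compound 2 (0.56 log units; beyond the scatter). A step of similar size toward a lower number is therefore expected in this assay, namely an at least 2.8-fold lower number from compound 1 to compound 3 (0.45 log units; beyond the scatter). The estimate for compound 3 is 35000 nM, with an expected range of 12000 nM to 100000 nM.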

Compound 3, half-maximal inhibitory concentration: > 100000 nM
Compound 3: a limit, no number; the forecaster's own chance of this, stated with the estimate: 25%; middle value at least 2.8-fold (0.45 log units) from the limit.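

With 3-nitrophenyl, the gain seen with 3-methylphenyl does not carry over: in this assay, nitro in place of methyl on an aromatic carbon gives an at least 3.6-fold higher number from compound 2 to compound 3 (0.56 log units; beyond the scatter). This shows that the group on that ring decides whether the compound stays at the limit, with compound 2 the only one of the three to give a number. The step between compound 1 and compound 3 cannot be read because both values are limits and not numbers: the limit of > 100000 nM in this assay, at which 2 of the 3 values shown sit. Open, on these data alone, is whether an amine or an ethyl group in that ring place would behave like methyl or like nitro.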